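Hydroxy Replaces Chloro: What to Expect for Compound 3

The source may report more compounds than this note shows. Statements on the series, on what has been measured and on what is new or still open speak of the compounds shown alone.

Of the compounds shown here, two have been measured in a functional assay on aorta (Rattus norvegicus, strain Sprague-Dawley) for inhibition, with a stated time of 20 min; a higher number here means a larger maximal response, a lower number a smaller maximal response. Compound 1 `O=C(/C=C/c1cccc(Br)c1)c1c(O)cc(O)cc1O` gives 99.8% in this assay, and compound 2 `C=CCc1c(O)cc(O)c2c1OC(c1ccc(Cl)cc1)CC2=O` gives 77.6%. Compound 2 thus holds the lower of the two numbers, and compound 1 lies higher by a margin beyond the usual scatter. Compound 3 `C=CCc1c(O)cc(O)c2c1OC(c1ccc(O)cc1)CC2=O` has not yet been measured. It differs from compound 2 by a single exchange: hydroxy in place of chloro on an aromatic carbon. Within the data shown here, no measured pair shows this kind of exchange, so its effect is unknown. A step close to the scatter, in either direction, is expected, estimated as a number 2.4 percentage points higher from compound 2 to compound 3 (within the scatter). Compound 3 is expected to reach about 80%, with a likely range from 60% to 98%.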

Compound 3, largest response reached (Emax), in percent of the reference or control that the assay uses: 9.86%
The estimate for compound 3 lay 70.1 percentage points above the measured number; the whole stated range lies above it.
By their numbers in this assay, from the lowest: compound 3; then compound 2; then compound 1.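

Among these compounds, the exchange of 4-chlorophenyl for 4-hydroxyphenyl gives the first readable step at this position: in this assay, it is a number 67.7 percentage points lower from compound 2 to compound 3 (beyond the scatter). A change of one small group on the aromatic ring, with the rest of the molecule unchanged, can therefore shift the maximal response far beyond the scatter. Nothing available explains why this step is so large. As far as these compounds go, whether an amine, a methoxy group or a carboxylic acid at this place would lower the response as well remains open. So does whether the same exchange would act similarly on a different core.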